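Swapping the amine substituent on compound 2's pyrimidine

The source may hold more compounds than are shown below. What is called first, only, known or untested is meant among the compounds shown, and "the series" means these compounds.

In a functional assay on COLO 205 cells (Homo sapiens) for antiproliferative activity, read by luminescence, with a stated time of 72 h (on this read-out lower numbers stand for stronger inhibition and higher numbers for weaker inhibition), compound 2 `O=C1N([C@H](CO)c2cccc(Cl)c2)Cc2cc(-c3nc(NC4CCOCC4)ncc3Cl)cn21` gives 104 nM, the lowest of the two numbers measured here. Compound 3 `Cc1cnc(Nc2ccnn2C)nc1N1Cc2nn(C(CO)c3cccc(Cl)c3)c(C)c2C1` gives 964 nM in this assay, a gap from compound 2 that lies beyond the usual scatter. Compound 1 `Cc1cnc(Nc2ccnn2C)nc1-c1cn2c(c1F)CN([C@H](CO)c1cccc(Cl)c1)C2=O` is reported in this assay as "not active" (no number reported), with no number attached, and it is built on a different core from compound 2.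

Compound 4 `Cn1nccc1Nc1ncc(Cl)c(-c2cc3n(c2)C(=O)N([C@H](CO)c2cccc(Cl)c2)C3)n1` is the compound still to be measured. It keeps the whole of compound 2 except for one group: 1-methyl-1H-pyrazol-5-yl in place of oxan-4-yl on a nitrogen on an aromatic ring. Going by the values given here, the same pyrazolylamine appears on the different cores of compound 1 and compound 3, where the results are weaker than those of compound 2, while no measured pair shows this exact exchange on the shared core of compound 2 and compound 4.

With this in mind, the expected step from compound 2 to compound 4 in this assay is a 2.1-fold higher number from compound 2 to compound 4 (0.33 log units; beyond the scatter), a modest move toward weaker inhibition, though one that may fall within the scatter. Compound 4 is therefore estimated at 220 nM in this assay, with a plausible range from 60 nM to 900 nM.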

Compound 4, half-maximal inhibitory concentration: 31.9 nM
Estimate against measurement, compound 4: 6.9-fold (0.84 log units) above, outside the stated range (below it).
By their numbers in this assay, from the lowest: compound 4; then compound 2; then compound 3.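

On the core shared by this pair, putting 1-methyl-1H-pyrazol-5-yl in place of oxan-4-yl on the nitrogen gives, in this assay, a 3.3-fold lower number from compound 2 to compound 4 (0.51 log units; beyond the scatter), a modest step toward stronger inhibition. Before this pair, the pyrazolylamine had been seen only on other cores, where compound 3 gives 964 nM and compound 1 is reported as "not active" (no number reported), and these differ from compound 2 in more than one place, so they could not isolate the effect of this exchange. This single change shows that, at this position on this core, a five-membered aromatic ring is tolerated and gives a lower number than the six-membered non-aromatic ring, although nothing measured here explains the step.

The compounds shown do not separate the contributions of the aromatic ring, its two ring nitrogens and its methyl group, and a phenyl group or an unmethylated 1H-pyrazol-5-yl group on the same nitrogen would help to pull these apart. As far as these compounds go, it also remains open whether the same exchange would lower the number on the cores of compound 1 and compound 3, where an oxan-4-ylamino group would provide the matching comparison.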